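Dropping a chloro from a growth-inhibiting acylhydrazone

The source may report more compounds than this note shows. Statements on the series, on what has been measured and on what is new or still open speak of the compounds shown alone.

Compound 1: `COc1ccc(OC)c(/C=C/c2nnc(Nc3ccc(Cl)cc3)o2)c1` — 3550 nM
Compound 2: `COc1ccc(OC)c(/C=C/C(=O)N/N=C/c2ccc(Cl)cc2)c1` — 33.5 nM

In a functional assay on OVCAR-3 cells (Homo sapiens) for antiproliferative activity, read by sulforhodamine B assay, with a stated time of 48 h (on this read-out lower numbers stand for stronger inhibition of growth and higher numbers for weaker inhibition of growth), compound 2 gives 33.5 nM, the lowest number of the two, and compound 1 gives 3550 nM, a gap well beyond the scatter. Compound 3, `COc1ccc(OC)c(/C=C/C(=O)N/N=C/c2ccccc2)c1`, differs from compound 2 by one change: hydrogen in place of chloro on an aromatic carbon. Among the measured compounds shown here, no single-change step between measured compounds shows how such a change plays out here, so only a moderate weakening in this assay is expected, as a 2.4-fold higher number from compound 2 to compound 3 (0.38 log units; beyond the scatter). Compound 3 is therefore estimated at 80 nM, within 25 nM to 250 nM.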

Compound 3, concentration for 50% growth inhibition: 3150 nM
Estimate against measurement, compound 3: 39-fold (1.60 log units) below; the whole stated range lies below it.
By their numbers in this assay, from the lowest: compound 2; then compounds 3 and 1 (each within the scatter of the next).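

In this assay, among the compounds shown here, the single change from 4-chlorophenyl to phenyl produces a 94-fold higher number from compound 2 to compound 3 (1.97 log units; beyond the scatter), a large weakening from the loss of one heavy atom. This place on the ring, para to a large group, therefore matters greatly for growth inhibition in this series. Nothing measured here explains why the step is so large.

Going by these compounds, it remains open whether chloro is specifically needed or whether another group, such as fluoro, methyl or methoxy, would serve equally well at this place. The effect of moving the chloro elsewhere on the ring is also unknown.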